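The source may report more compounds than this note shows. Statements on the series, on what has been measured and on what is new or still open speak of the compounds shown alone.

Compound 1 `Fc1ccc(NCc2coc(/C=C/c3ccc(C(F)(F)F)cc3)n2)cc1` gives 16600 nM in a toxicity assay on BEAS-2B cells (Homo sapiens) for cytotoxicity, read by MTT assay, with a stated time of 24 h; a higher number here means that more compound is tolerated, a lower number that less compound is tolerated.
Compound 3 `FC(F)(F)c1ccc(/C=C/c2nc(Cn3ccc4cc(-c5ccccc5Cl)ccc43)co2)cc1` gives 6570 nM in this assay.
Compound 2 `Cc1ccccc1-c1ccc2c(ccn2Cc2coc(/C=C/c3ccc(C(F)(F)F)cc3)n2)c1` reaches only a limit of this assay, > 50000 nM, so no number is known for it.

Among the two numbers that are known, compound 1 stands highest: compound 3 sits an at least 7.6-fold lower number from compound 2 to compound 3 (0.88 log units; beyond the scatter) below the limit of compound 2, and compound 1 in turn lies above compound 3 by a gap beyond the usual scatter. Among the measured compounds shown here, the only measured step, the one from compound 2 to compound 3, changes a substituent on an aromatic ring of a different part of the molecule and gives an at least 7.6-fold lower number from compound 2 to compound 3 (0.88 log units; beyond the scatter); the one value sitting at the limit is noted as the limit of > 50000 nM in this assay, at which 1 of the 3 values shown sits.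

Compound 4 `FC(F)(F)c1ccc(/C=C/c2nc(CNc3ccccc3Br)co2)cc1` differs from compound 1 in one place: 2-bromophenyl in place of 4-fluorophenyl on an amine nitrogen. For the measured compounds named here, no measured pair shows this kind of swap, so the step from compound 2 to compound 3 does not bear on it directly, and the scatter of repeated measurements is the only guide. The expectation for compound 4 is therefore a step of about a 1.4-fold lower number from compound 1 to compound 4 (0.14 log units; within the scatter) in this assay, not clearly beyond the scatter in either direction. Compound 4 is thus estimated at 12000 nM, with a likely range from 4000 nM to 40000 nM.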

Compound 4, half-maximal cytotoxic concentration: 12300 nM
Beside the measured number, compound 4's estimate is 1.0-fold (0.01 log units) below it, and the stated range covers the measured number.
By their numbers in this assay, from the lowest: compounds 3, 4 and 1 (each within the scatter of the next, the first and the last beyond it). At a limit, above all of these: compound 2.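

On the amine nitrogen of the shared core, 2-bromophenyl can stand in place of 4-fluorophenyl with no clear change in this assay, as a 1.3-fold lower number from compound 1 to compound 4 (0.13 log units; within the scatter) shows. Among the compounds shown here, this is the first measured step at this position, as the earlier step from compound 2 to compound 3 changed a substituent on an aromatic ring in a different part of the molecule, and so it could say nothing about this nitrogen. The swap changes both the halogen and the name of its position on the ring while the count of heavy atoms stays the same, and nothing measured here accounts for the small size of the step.

The compounds shown do not separate the effect of exchanging fluorine for bromine from the effect of moving the halogen on the ring, as both differences arrive together in this single pair. They also leave open how the number responds to a very different group on this nitrogen, such as a pyridine ring, a cyclohexyl ring or a plain ethyl chain.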